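The source may report more compounds than this note shows. Statements on the series, on what has been measured and on what is new or still open speak of the compounds shown alone.

Measured compounds:
- compound 1 `Cc1ccc(C(=O)c2ccc3c(ccn3Cc3ccc(C(=O)NO)cc3)c2)cc1`: 1490 nM
- compound 2 `COc1cc(C(=O)c2ccc3c(ccn3Cc3ccc(/C=C/C(=O)NO)cc3)c2)cc(OC)c1OC`: 2170 nM
- compound 3 `COc1cc(C(=O)c2ccc3c(ccn3S(=O)(=O)c3ccc(/C=C/C(=O)NO)cc3)c2)cc(OC)c1OC`: 5340 nM

In an assay on isolated protein for inhibition of histone deacetylase 8 (Homo sapiens) (on this read-out lower numbers stand for stronger inhibition and higher numbers for weaker inhibition), compound 1 has the lowest of the three numbers. Compound 2 lies within the scatter of compound 1, so no order between the two can be read from these values. Compound 3 is the furthest from compound 1, and that gap lies beyond the scatter. No single-point comparison between any two of the measured compounds is available, so nothing more than the bare values can be said of how compound 1 relates to compound 2 and compound 3.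

The next compound, compound 4 `O=C(NO)c1ccc(Cn2ccc3cc(C(=O)c4ccc(F)cc4)ccc32)cc1`, differs from compound 1 in one place: fluoro in place of methyl on an aromatic carbon. The shared core of compound 1 is kept, as is the hydroxamic acid side of the molecule.

For the measured compounds named here, nothing among the measured compounds tests an exchange of this kind, so the expectation rests on the size of the change alone. A swap of one heavy atom for one heavy atom, neither adding nor removing a hydrogen-bond donor or acceptor, is expected to give a step from compound 1 to compound 4 of a 1.1-fold higher number from compound 1 to compound 4 (0.03 log units; within the scatter), that is, nothing beyond the scatter in either direction. Compound 4 is therefore estimated to give 1600 nM in this assay, expected to fall between 700 nM and 3600 nM.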

Compound 4, half-maximal inhibitory concentration: 1240 nM
For compound 4 the middle estimate is 1.3-fold (0.11 log units) above the measured one; the measured number falls inside the stated range.
By their numbers in this assay, from the lowest: compounds 4, 1 and 2 (each within the scatter of the next); then compound 3.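

In this assay, for the compounds shown here, the step of a 1.2-fold lower number from compound 1 to compound 4 (0.08 log units; within the scatter) is the first comparison that changes one place only: fluoro in place of methyl on an aromatic carbon, para to a large group. The earlier compounds shown here differ from one another in more than one place and could not isolate this position, whereas here 4-methylphenyl goes to 4-fluorophenyl with the shared core and the hydroxamic acid side kept, and the read-out stays within the scatter, so these two groups cannot be told apart at this position. No measurement at hand bears on why the two groups read alike.

Going by these compounds alone, only methyl and fluoro can be compared at this position so far, so it remains open whether an amine, a carboxylic acid or a longer chain placed there would move the number beyond the scatter. On these data alone, it is also open whether the same exchange would read alike on the side chain carried by compound 2, where the hydroxamic acid stands on a different linker.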